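Chain length at the alkylidene carbon of the trimethoxyphenyl series

A few compounds are considered here, and "the series" means these few. Any claim that something is new, unique, unknown or untested is made for them only; others in the source may bear on it.

Measured so far:
Compound 1, `CC/C(=C\c1cc(OC)c(OC)c(OC)c1)C(=O)N1CCC=C(Cl)C1=O`: 19000 nM
Compound 2, `CCCC/C(=C\c1cc(OC)c(OC)c(OC)c1)C(=O)N1CCC=C(Cl)C1=O`: 14800 nM
Compound 3, `COc1cc(/C=C/C(=O)N2CCC=C(Br)C2=O)cc(OC)c1OC`: 8090 nM

All three numbers come from a functional assay on Hep 3B2 cells (Homo sapiens) for cytotoxicity, read by MTT assay, with a stated time of 72 h; a lower number here means a stronger inhibitor, a higher number a weaker inhibitor. Compound 2 gives the second highest of the three numbers; its nearest neighbour is compound 1, and the step of a 1.3-fold lower number from compound 1 to compound 2 (0.11 log units; within the scatter) is within the scatter. Compound 3 carries the bromo core and lacks the alkyl chain, and its value against that of compound 2 lies within the scatter as well, so no ordering among the three can be claimed.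

Compound 4, `CCC/C(=C\c1cc(OC)c(OC)c(OC)c1)C(=O)N1CCC=C(Cl)C1=O`, differs from compound 2 by hydrogen in place of methyl on a saturated chain carbon, three bonds along the chain from a double-bonded chain carbon. Going by the values given here, the only measured step that bears on this kind of change is the one from compound 1 to compound 2, and it was within the scatter. Compound 4 sits between those two in chain length, so in this assay no shift beyond the scatter is expected: the step of a 1.1-fold higher number from compound 2 to compound 4 (0.05 log units; within the scatter) is the estimated outcome. The expected value for compound 4 is 16500 nM, with a range from 8000 nM to 34000 nM.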

Compound 4, half-maximal inhibitory concentration: 22400 nM
Compound 4: middle estimate off by 1.4-fold (0.13 log units), on the low side, and the stated range covers the measured number.
By their numbers in this assay, from the lowest: compounds 3, 2, 1 and 4 (each within the scatter of the next, the first and the last beyond it).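

In this assay, propyl at this position now fills the gap between ethyl and butyl, and both new steps, a 1.5-fold higher number from compound 2 to compound 4 (0.18 log units; within the scatter) and a 1.2-fold higher number from compound 1 to compound 4 (0.07 log units; within the scatter), stay within the scatter, as did the earlier step between ethyl and butyl. The earlier pair could have hidden a distinct value at the intermediate length, but with compound 4 in hand, the ethyl, propyl and butyl chains on the shared core cannot be ordered, and the three compounds show no dependence on chain length. Nothing available here bears on why these chains cannot be told apart.

Open, on these data alone, is whether a much longer chain such as octyl, or a branched one such as isopropyl, would give a step beyond the scatter. Also open, as far as these compounds go, is whether an amine or a carboxylic acid at the end of the chain would do so.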